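From 5-methylfuran-2-yl to 3-methylphenyl on a shared core

The source may hold more compounds than are shown below. What is called first, only, known or untested is meant among the compounds shown, and "the series" means these compounds.

- Compound 1 `Cc1ccsc1-c1cc(-c2ccco2)cc(-c2ccccc2Cl)n1` measured at 25400 nM
- Compound 2 `Cc1ccc(-c2cc(-c3ccoc3)cc(-c3ccc(Cl)s3)n2)o1` measured at 12700 nM

In a functional assay on K562 cells (Homo sapiens) for cytotoxicity, read by ELISA, with a stated time of 4 days (a higher number here means a weaker inhibitor, a lower number a stronger inhibitor), compound 2 at 12700 nM stands within the usual scatter of compound 1 at 25400 nM and is not separated from it. Compound 3 `Cc1cccc(-c2cc(-c3ccoc3)cc(-c3ccc(Cl)s3)n2)c1` carries 3-methylphenyl in place of 5-methylfuran-2-yl on an aromatic carbon and otherwise matches compound 2. Going by the values given here, no measured pair shows this change, so in this assay no step beyond the scatter is expected. The estimated step of a 1.1-fold lower number from compound 2 to compound 3 (0.02 log units; within the scatter) is expected to stay small. For compound 3 the estimated value is 12000 nM with an expected range from 4000 nM to 35000 nM in this measurement.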

Compound 3, half-maximal inhibitory concentration: 13700 nM
For compound 3 the middle estimate is 1.1-fold (0.06 log units) below the measured one; measured number inside the range.
By their numbers in this assay, from the lowest: compounds 2, 3 and 1 (each within the scatter of the next).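

In this assay, 3-methylphenyl in place of 5-methylfuran-2-yl on the aromatic carbon next to the ring nitrogen gives a 1.1-fold higher number from compound 2 to compound 3 (0.03 log units; within the scatter) as the first step read at this position. Here, a six-membered aromatic ring of carbon only and a five-membered aromatic ring with 1 hetero atom are not separated. Nothing available on these compounds explains this result. The compounds shown leave open whether an amine or a carboxylic acid on this carbon would give a step beyond the scatter.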